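The source may report more compounds than this note shows. Statements on the series, on what has been measured and on what is new or still open speak of the compounds shown alone.

Compound 1 `C=C1C(=O)O[C@H]2[C@H]1CC/C(COC(=O)CCC(=O)OCn1cc(F)c(=O)[nH]c1=O)=C\CC[C@@]1(C)O[C@@H]21`: > 20000 nM (a limit)
Compound 2 `C=C1C(=O)O[C@H]2[C@H]1CC/C(COC(=O)Cn1cc(F)c(=O)n(Cc3ccc(C(F)(F)F)cc3)c1=O)=C\CC[C@@]1(C)O[C@@H]21`: 2250 nM

Among the measured compounds shown here, in a functional assay on Bel-7402 cells (Homo sapiens) for antiproliferative activity, read by MTT assay, with a stated time of 72 h (on this read-out higher numbers stand for weaker inhibition and lower numbers for stronger inhibition), compound 2 gives 2250 nM, the only true number so far. Compound 1 reads > 20000 nM, which is a limit and not a number. Compound 3 `C=C1C(=O)O[C@H]2[C@H]1CC/C(COC(=O)Cn1cc(F)c(=O)n(C)c1=O)=C\CC[C@@]1(C)O[C@@H]21` is still unmeasured; the change from compound 2 is hydrogen in place of 4-(trifluoromethyl)phenyl on a saturated chain carbon bound to an aromatic nitrogen, that is, 4-(trifluoromethyl)benzyl to methyl. For the measured compounds named here, no pair of measured compounds isolates this change, so the expectation is tentative. Weaker inhibition in this assay is expected, with an estimated step of a 3.1-fold higher number from compound 2 to compound 3 (0.49 log units; beyond the scatter). Compound 3 is estimated at 7000 nM, with an expected range of 2500 nM to 20000 nM.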

Compound 3, half-maximal inhibitory concentration: 9400 nM
For compound 3 the middle estimate is 1.3-fold (0.13 log units) below the measured one; low and high end bracket the measured number.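

In this assay, among the compounds shown here, the change from 4-(trifluoromethyl)benzyl to methyl on the aromatic nitrogen gives the first readable step at this position: a 4.2-fold higher number from compound 2 to compound 3 (0.62 log units; beyond the scatter). Compound 3 still gives a true number without the aromatic ring, so the ring is not needed for a measurable value, though the step is modest. Compound 1 remains a limit, and steps involving it cannot be read: the limit of > 20000 nM in this assay, at which 1 of the 3 values shown sits.

Going by these compounds, what a plain benzyl or a longer chain such as n-butyl would give here remains open. The share of the trifluoromethyl group in this step therefore cannot be separated from that of the phenyl ring.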